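Swapping Imidazole for Pyrimidine on the Shared Core

A few compounds are considered here, and "the series" means these few. Any claim that something is new, unique, unknown or untested is made for them only; others in the source may bear on it.

Values measured in an in vivo ADME assay on the whole organism (strain 129/SvEvBrd x C57BL/6) for pharmacokinetics, with Mus musculus as the target (on this read-out higher numbers stand for higher oral bioavailability and lower numbers for lower oral bioavailability), for three compounds

Compound 1 `CC(O)c1nc([C@@H](O)[C@H](O)[C@H](O)CO)c[nH]1` gives 22%
Compound 2 `CN(C)C(=O)c1nc([C@@H](O)[C@H](O)[C@H](O)CO)c[nH]1` gives 5%
Compound 3 `OC[C@@H](O)[C@@H](O)[C@H](O)c1c[nH]c(-c2ncc[nH]2)n1` gives 28%

Two steps place compound 3 among these numbers. The measurements show a number 6 percentage points higher from compound 1 to compound 3 (within the scatter) and also a number 23 percentage points higher from compound 2 to compound 3 (beyond the scatter) on the same scale.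

Compound 4 `OC[C@@H](O)[C@@H](O)[C@H](O)c1c[nH]c(-c2ncccn2)n1` carries pyrimidin-2-yl in place of 1H-imidazol-2-yl on an aromatic carbon. Among the measured compounds shown here, the change counts out as pyrimidin-2-yl in place of 1H-imidazol-2-yl on an aromatic carbon and no measured step makes this exchange.

The nearest evidence comes from other exchanges at the same place. These reach modest size in a number 17 percentage points lower from compound 1 to compound 2 (beyond the scatter) and in a number 23 percentage points higher from compound 2 to compound 3 (beyond the scatter) but both involve dimethylcarbamoyl, which is absent here. For the measured compounds named here, the one exchange between the other two groups gives a number 6 percentage points higher from compound 1 to compound 3 (within the scatter) without leaving the scatter. With compound 3 at 28% as the starting point, no change beyond the scatter is expected. The expected step is a number 4 percentage points lower from compound 3 to compound 4 (within the scatter) by this estimate. Compound 4 is estimated at 24% with an expected range from 10% to 42% in this reading.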

Compound 4, oral bioavailability: 7%
Compound 4: the middle estimate sits 17 percentage points above what was measured; measured number below the stated range.
By their numbers in this assay, from the lowest: compounds 2 and 4 (each within the scatter of the next); then compounds 1 and 3 (each within the scatter of the next).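

In this assay, the place between two ring nitrogen atoms turns out to be sensitive to which aromatic ring it carries, with a number 21 percentage points lower from compound 3 to compound 4 (beyond the scatter) on going from a five-membered ring with a hydrogen-bond donor to a six-membered ring without one. An aromatic ring with two nitrogen atoms at this place therefore does not by itself keep the number up: pyrimidin-2-yl gives a number 15 percentage points lower from compound 1 to compound 4 (beyond the scatter) against 1-hydroxyethyl and a number 2 percentage points higher from compound 2 to compound 4 (within the scatter) against dimethylcarbamoyl, so it groups with dimethylcarbamoyl rather than with 1H-imidazol-2-yl. Nothing available here accounts for this difference.

Ring size and the hydrogen-bond donor change together in this step, so the compounds shown cannot separate them. A pyridin-2-yl group, or a methyl on the ring nitrogen of the 1H-imidazol-2-yl group, would bear on that question.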